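The source may report more compounds than this note shows. Statements on the series, on what has been measured and on what is new or still open speak of the compounds shown alone.

Of the compounds shown here, three built on one shared core have been tested in a functional assay on DU-145 cells (Homo sapiens) for cytotoxicity, read by CCK-8 assay; on this read-out higher numbers stand for weaker inhibition and lower numbers for stronger inhibition. Compound 1 `Oc1ccc(-c2cc(-c3ccco3)cc(-c3ccccc3O)n2)cc1` gives only a limit of the assay, > 50000 nM. For the measured compounds named here, compound 2 `Oc1ccc(-c2cc(-c3ccccn3)cc(-c3ccccc3O)n2)cc1` gives 25400 nM, the single number among the three. Compound 3 `Oc1ccc(-c2cc(-c3ccccn3)cc(-c3ccc(O)cc3)n2)cc1` likewise gives a limit of the assay, > 50000 nM. Compound 2 thus stands alone as a measured value, the others resting at the limit of > 50000 nM in this assay, at which 2 of the 3 values shown sit. Compound 4 `Oc1ccc(-c2cc(-c3cccnc3)cc(-c3ccccc3O)n2)cc1` differs from compound 2 by pyridin-3-yl in place of pyridin-2-yl on an aromatic carbon. The measured steps nearest to this change are an at least 1.9-fold lower number from compound 1 to compound 2 (0.29 log units; that floor lies within the scatter) and an at least 1.9-fold higher number from compound 2 to compound 3 (0.29 log units; that floor lies within the scatter), both floors within the scatter, so no clear direction emerges. Compound 4 is therefore expected near 35000 nM, within 15000 nM to 80000 nM. The expected step of a 1.4-fold higher number from compound 2 to compound 4 (0.14 log units; within the scatter) should stay within the scatter, though a limit remains possible.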

Compound 4, half-maximal inhibitory concentration: > 50000 nM
Compound 4: a limit, no number; the forecaster's own chance of this, stated with the estimate: 40%; middle value at least 1.4-fold (0.15 log units) from the limit.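

Placing pyridin-3-yl in place of pyridin-2-yl, opposite the ring nitrogen, gives an at least 1.9-fold higher number from compound 2 to compound 4 (0.29 log units; that floor lies within the scatter); compound 4 gives a limit and not a number, so this is only a floor. The step from compound 1 to compound 4 cannot be read, as both ends are limits. Of the furan-2-yl, pyridin-2-yl and pyridin-3-yl groups at this position, only compound 2, with pyridin-2-yl, gives a number: the limit of > 50000 nM in this assay, at which 3 of the 4 values shown sit.

Still open, on these data alone, is whether a pyridin-4-yl group, a plain phenyl ring or an amine at this position would give a number in this assay.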